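The compounds below may be only part of what the source reports. "The series", "measured", "known", "first", "only" and "open" are said of these compounds alone.

Measured in a functional assay on HeLa cells (Homo sapiens) for inhibition, read by sulforhodamine B assay; a higher number here means a weaker inhibitor, a lower number a stronger inhibitor:
compound 1, `Cc1ccc(NC2=CC(=O)c3c(nc4n3[C@H]3OC[C@@H](O)[C@H]3OC4)C2=O)cc1`: 6590 nM
compound 2, `O=C1C=C(Nc2ccc(C(F)(F)F)cc2)C(=O)c2c1nc1n2[C@H]2OC[C@@H](O)[C@H]2OC1`: > 8000 nM

Compound 1 holds the only numbered result in this assay. Compound 2 sits at the limit of > 8000 nM in this assay, at which 1 of the 2 values shown sits, which is a limit of the assay and not a number. Compound 3, `COc1cccc(NC2=CC(=O)c3c(nc4n3[C@H]3OC[C@@H](O)[C@H]3OC4)C2=O)c1`, has not yet been measured; it differs from compound 1 by 3-methoxyphenyl in place of 4-methylphenyl on an amine nitrogen. For the measured compounds named here, no measured pair gauges this exchange, so the step from compound 1 to compound 3 is expected to stay within the usual scatter, a 1.1-fold higher number from compound 1 to compound 3 (0.03 log units; within the scatter). Compound 3 is therefore estimated at 7000 nM, with a range from 3000 nM to 16000 nM.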

Compound 3, half-maximal inhibitory concentration: > 8000 nM
Compound 3: no number, only a limit; the forecaster's own chance of this, stated with the estimate: 35%; middle value at least 1.1-fold (0.05 log units) away from the limit.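

In this assay compound 3 gives no number, only a limit, so 3-methoxyphenyl in place of 4-methylphenyl on the amine nitrogen can be read only as a floor, an at least 1.2-fold higher number from compound 1 to compound 3 (0.08 log units; that floor lies within the scatter), and it does not separate the two compounds. The exchange brings no gain in strength, while any loss remains unsized. The results for this position now gather at the limit: the limit of > 8000 nM in this assay, at which 2 of the 3 values shown sit.

On these data alone, how far compound 3 lies past its limit stays open. So does whether an aminophenyl or a carboxylic acid on this phenyl ring would give a number.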